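Same amide-end swap, carried onto a second core

This account rests on a few compounds, and the source may have more. Where it says the series, first, only, none or still open, it means among the compounds named here.

Compound 1 `CCn1c(C(=O)NCC(OC)OC)ccc1C(CC)(CC)c1ccc(OCC(=O)C(C)(C)C)c(C)c1` gives 130 nM in an assay on HL-60 cells for agonist activity at vitamin D3 receptor (Homo sapiens), read by microscopy, with a stated time of 96 h; a higher number here means that more compound is needed for the effect, a lower number that less compound is needed. Compound 2 `CCn1c(C(=O)NCCN)ccc1C(CC)(CC)c1ccc(OCC(=O)C(C)(C)C)c(C)c1` gives 120 nM in this assay, and compound 3 `CCn1c(C(=O)NCC(OC)OC)ccc1C(CC)(CC)c1ccc(OCC(O)C(C)(C)C)c(C)c1` gives 150 nM. Compound 1 and compound 2 differ only at the amide end of the molecule, (aminomethyl in place of dimethoxymethyl on a saturated chain carbon bound to an amide-type nitrogen), and the outcome was a 1.1-fold lower number from compound 1 to compound 2 (0.03 log units; within the scatter). Compound 1 and compound 3 differ instead in the group hanging off the aromatic ring, (1-hydroxy-2,2-dimethylpropyl in place of (tert-butyl)carbonyl on a saturated chain carbon bound to an oxygen on an aromatic ring), with the step of a 1.2-fold higher number from compound 1 to compound 3 (0.06 log units; within the scatter). Compound 4 `CCn1c(C(=O)NCCN)ccc1C(CC)(CC)c1ccc(OCC(O)C(C)(C)C)c(C)c1` has not yet been measured. Within the data shown here, it carries the core of compound 3 and differs from compound 3 by aminomethyl in place of dimethoxymethyl on a saturated chain carbon bound to an amide-type nitrogen, which is the same change, in the same place, as the one from compound 1 to compound 2. Since that earlier step stayed within the scatter, the step from compound 3 to compound 4 is expected to be about as small, a 1.1-fold lower number from compound 3 to compound 4 (0.03 log units; within the scatter). The estimate for compound 4 in this assay is therefore 140 nM, with a likely range from 70 nM to 280 nM.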

Compound 4, half-maximal effective concentration: 10 nM
For compound 4 the middle estimate is 14-fold (1.15 log units) above the measured one; the whole stated range lies above it.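

In this assay, putting aminomethyl in place of dimethoxymethyl gave a 15-fold lower number from compound 3 to compound 4 (1.18 log units; beyond the scatter) on the core carrying the 1-hydroxy-2,2-dimethylpropyl group, and that size did not carry over from the core with the (tert-butyl)carbonyl group: the same change on two cores in this assay, a 1.1-fold lower number (0.03 log units; within the scatter) from compound 1 to compound 2 and a 15-fold lower number (1.18 log units; beyond the scatter) from compound 3 to compound 4, 14-fold (1.14 log units) apart, beyond the scatter of two such steps The other change, 1-hydroxy-2,2-dimethylpropyl in place of (tert-butyl)carbonyl, likewise gave a 12-fold lower number from compound 2 to compound 4 (1.08 log units; beyond the scatter) once aminomethyl was present, and it too depends on its surroundings: the same change on two cores in this assay, a 1.2-fold higher number (0.06 log units; within the scatter) from compound 1 to compound 3 and a 12-fold lower number (1.08 log units; beyond the scatter) from compound 2 to compound 4, 14-fold (1.14 log units) apart, beyond the scatter of two such steps These four compounds therefore show that the two changes do not add up independently, since each does little alone and the large drop appears only in compound 4, which carries both; they do not show why this happens, or whether it holds beyond these four compounds.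

The compounds shown leave open whether a longer chain such as 3-aminopropyl, or a dimethylamino group at the amide end, would give a similar number alongside the hydroxyl-bearing group. They also leave open what a carboxylic acid at the amide end, or a methyl ether in place of the hydroxyl group, would do.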